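A Fluorine Added to an Anilino Compound at the Assay Limit

The compounds below may be only part of what the source reports. "The series", "measured", "known", "first", "only" and "open" are said of these compounds alone.

Compound 1 `O=C1C(Nc2ccccc2)=CC(=O)c2c1nc1n2[C@H]2OC[C@@H](O)[C@H]2OC1`: in a functional assay on HeLa cells (Homo sapiens) for inhibition, read by sulforhodamine B assay (a higher number here means a weaker inhibitor, a lower number a stronger inhibitor), compound 1 gives > 8000 nM, a limit of the assay rather than a number.
Compound 2 `O=C1C=C(N2CCC2)C(=O)c2c1nc1n2[C@H]2OC[C@@H](O)[C@H]2OC1`: compound 2 gives > 16000 nM, again only a limit.
Compound 3 `O=C1C=C(Nc2ccccc2)C(=O)c2c1nc1n2[C@H]2OC[C@@H](O)[C@H]2OC1`: compound 3 gives 5620 nM.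

Compound 1 therefore stands at the weak end of what is shown: its value is a limit, so only an upper bound on its potency is known. Compound 3 carries the same anilino group on the other double-bonded ring carbon of the shared core and is the only one of the three with a measured number.

Compound 4 `O=C1C(Nc2cccc(F)c2)=CC(=O)c2c1nc1n2[C@H]2OC[C@@H](O)[C@H]2OC1` differs from compound 1 by a single change, (fluoro in place of hydrogen on an aromatic carbon).

For the measured compounds named here, the one measured step, an at least 2.8-fold lower number from compound 2 to compound 3 (0.45 log units; beyond the scatter), swaps the whole group on the ring carbon and says nothing about a fluoro added to the ring of an anilino group; no measured step bears directly on the change from compound 1 to compound 4. With compound 1 sitting at a limit, no step beyond the scatter can be foreseen, and the most likely outcome is another limit. Compound 4 is expected to give 12000 nM in this assay, with a range from 5000 nM to 30000 nM, which is an expected step that the limit leaves unreadable from compound 1 to compound 4.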

Compound 4, half-maximal inhibitory concentration: > 8000 nM
Compound 4: no number, only a limit; the forecaster's own chance of this, stated with the estimate: 65%; the middle value is on the limit's open side.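

In this assay compound 4 gives > 8000 nM, a limit and not a number. Compound 1 and compound 4 both sit at a limit, so no step can be read between them: the limit of > 8000 nM in this assay, at which 2 of the 4 values shown sit.

Left open is whether the fluoro on the anilino ring changes the potency at all, as neither compound has a measured number.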